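The compounds below may be only part of what the source reports. "The series", "measured", "known", "first", "only" and "open" are said of these compounds alone.

Compound 1, with the structure `Cc1ccc2nc(N)nc(O)c2c1Sc1ccc(C(=O)N[C@H](C(=O)O)c2ccccc2)cc1`, and compound 2, with the structure `Cc1ccc2nc(N)nc(O)c2c1Sc1ccc(C(=O)N[C@H](C(=O)O)c2cccc(O)c2)cc1`, share one core and differ only at one point: hydroxy in place of hydrogen on an aromatic carbon. In a functional assay on CCRF-CEM cells (Homo sapiens) (a higher number here means a weaker inhibitor, a lower number a stronger inhibitor), compound 1 gives 5400 nM, and compound 2 gives 3400 nM, so the step of a 1.6-fold lower number from compound 1 to compound 2 (0.20 log units; within the scatter) is small.

Compound 3, with the structure `COC(=O)[C@@H](NC(=O)c1ccc(Sc2c(C)ccc3nc(N)nc(O)c23)cc1)c1ccccc1`, differs from compound 1 at a different point: methyl in place of hydrogen on an oxygen next to a carbonyl group. In this assay compound 3 gives 200 nM; the step of a 27-fold lower number from compound 1 to compound 3 (1.43 log units; beyond the scatter) and the step of a 17-fold lower number from compound 2 to compound 3 (1.23 log units; beyond the scatter) are both large, and compound 3 is the strongest inhibitor of the three measured compounds.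

Compound 4, with the structure `COC(=O)[C@@H](NC(=O)c1ccc(Sc2c(C)ccc3nc(N)nc(O)c23)cc1)c1cccc(O)c1`, has not been measured yet. It differs from compound 3 by hydroxy in place of hydrogen on an aromatic carbon. For the measured compounds named here, this is the same change as the one from compound 1 to compound 2, made on the core of compound 3 instead. Because the earlier step of a 1.6-fold lower number from compound 1 to compound 2 (0.20 log units; within the scatter) was small, the step of a 1.5-fold lower number from compound 3 to compound 4 (0.19 log units; within the scatter) is expected to be small as well. Compound 4 is therefore estimated to give about 130 nM in this assay, with a likely range from 60 nM to 300 nM.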

Compound 4, half-maximal inhibitory concentration: 1500 nM
Estimate against measurement, compound 4: 12-fold (1.06 log units) below; the whole stated range lies below it.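

Going from phenyl to 3-hydroxyphenyl does not carry over from one core to the other in this assay: on the methyl ester core it gives a 7.5-fold higher number from compound 3 to compound 4 (0.88 log units; beyond the scatter), and the two steps differ by more than the scatter: the same change on two cores in this assay, a 1.6-fold lower number (0.20 log units; within the scatter) from compound 1 to compound 2 and a 7.5-fold higher number (0.88 log units; beyond the scatter) from compound 3 to compound 4, 12-fold (1.08 log units) apart, beyond the scatter of two such steps

Read the other way, methyl in place of the acid hydrogen still lowers the number when the 3-hydroxyphenyl group is present, with a 2.3-fold lower number from compound 2 to compound 4 (0.36 log units; beyond the scatter), but by much less than with plain phenyl: the same change on two cores in this assay, a 27-fold lower number (1.43 log units; beyond the scatter) from compound 1 to compound 3 and a 2.3-fold lower number (0.36 log units; beyond the scatter) from compound 2 to compound 4, 12-fold (1.08 log units) apart, beyond the scatter of two such steps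

These four compounds show that the two changes do not act independently here, but they do not show why, or whether the same holds on any other core.

From the compounds shown here alone, it remains open whether the rise on the ester core belongs to hydroxy itself or would also follow from a methoxy group, a fluorine atom or an amine at the same place. Going by these compounds, it is also open whether an ethyl ester or a primary amide in place of the methyl ester would behave in the same way.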